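Cyclopropylidene series: fibroblast tolerance at the assay ceiling

The source may hold more compounds than are shown below. What is called first, only, known or untested is meant among the compounds shown, and "the series" means these compounds.

Working notes on the shared core. Compound 1 `Nc1nc(OCC(F)(F)F)c2ncn(/C=C3/CC3(CO)CO)c2n1` bears a 2,2,2-trifluoroethoxy group, compound 2 `COCCOc1nc(N)nc2c1ncn2/C=C1/CC1(CO)CO` a 2-methoxyethoxy group and compound 3 `Nc1nc(NCc2ccccc2)c2ncn(/C=C3/CC3(CO)CO)c2n1` a benzylamino group. In an ADME assay on HFF cells (Homo sapiens) for cytotoxicity, with a stated time of 8 days (a higher number here means that more compound is tolerated, a lower number that less compound is tolerated), compound 1 gives > 300000 nM, a limit of the assay rather than a number. In this assay compound 2 gives > 300000 nM, again only a limit. Compound 3 in this assay gives > 300000 nM, also a limit. All three values sit at the limit of > 300000 nM in this assay, at which 3 of the 3 values shown sit, so the steps a step that the two limits leave unreadable from compound 1 to compound 2, a step that the two limits leave unreadable from compound 1 to compound 3 and a step that the two limits leave unreadable from compound 2 to compound 3 cannot be read. Compound 2 therefore stands at the limit, with nothing separating it from the other two.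

Compound 4 `CC(C)Sc1nc(N)nc2c1ncn2/C=C1/CC1(CO)CO` differs from compound 2 by isopropylsulfanyl in place of 2-methoxyethoxy on an aromatic carbon. The measured steps bear on this change only in that none of them became readable; no change shown here brought the value below the limit. For compound 4 the expected step is a number no higher from compound 2 to compound 4 (the limit leaves the size open), most likely no change beyond the scatter and once more a limit. The estimate for compound 4 is 300000 nM, within 100000 nM to 1000000 nM.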

Compound 4, half-maximal cytotoxic concentration: > 300000 nM
Compound 4: only a limit was reported (the forecaster's own chance of this, stated with the estimate: 85%); the middle value sits exactly at the limit.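

No step between compound 4 and compound 1, compound 2 or compound 3 can be read, because all four values are the same assay limit: the limit of > 300000 nM in this assay, at which 4 of the 4 values shown sit.

The compounds shown leave open how far tolerance in this assay differs among these four groups on the shared core, and which change, if any, would bring a value off the limit.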